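This account rests on a few compounds, and the source may have more. Where it says the series, first, only, none or still open, it means among the compounds named here.

Measured compounds: compound 1 `COCc1ccc(-n2c(SC(C)c3ccccc3)nc3c(cnn3C)c2=O)cc1` gives 61% in an assay on isolated protein for inhibition of retinal dehydrogenase 2 (Homo sapiens), tested at 5 uM; a lower number here means less inhibition, a higher number more inhibition at the concentration tested (going by the name of the read-out); compound 2 `CC(Sc1nc2c(cnn2C)c(=O)n1-c1ccc(CN)cc1)c1ccccc1` gives 64% in this assay; compound 3 `COCCc1ccc(-n2c(SC(C)c3ccccc3)nc3c(cnn3C)c2=O)cc1` gives 54% in this assay.

Compound 3 sits at the low end of the three numbers, yet a number 7 percentage points lower from compound 1 to compound 3 (within the scatter) and a number 10 percentage points lower from compound 2 to compound 3 (within the scatter) both remain within the scatter, so the three compounds are not separated. Compound 4 `CNCc1ccc(-n2c(SC(C)c3ccccc3)nc3c(cnn3C)c2=O)cc1` is the unmeasured neighbour of compound 3, and the change is methylamino in place of methoxymethyl on a saturated chain carbon bound to an aromatic carbon. The step that bears on it is the reversed change from compound 2, where a number 10 percentage points lower from compound 2 to compound 3 (within the scatter); undoing that change and adding a methyl should, by this single comparison, give at most a small rise, because a number 10 percentage points lower from compound 2 to compound 3 (within the scatter) was itself within the scatter. Compound 4 is therefore expected to show a number 6 percentage points higher from compound 3 to compound 4 (within the scatter), nothing beyond the scatter. Compound 4 is estimated at 60%, between 48% and 72%.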

Compound 4, a percentage reported as inhibition, at one concentration (the size of the read-out at that concentration, not a potency): 70%
Beside the measured number, compound 4's estimate is 10 percentage points below it; the measured number falls inside the stated range.
By their numbers in this assay, from the lowest: compounds 3, 1, 2 and 4 (each within the scatter of the next, the first and the last beyond it).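

In this assay the change reads a number 16 percentage points higher from compound 3 to compound 4 (beyond the scatter), the first step among these compounds to lie beyond the scatter, so methylamino in place of methoxymethyl does separate two compounds on this saturated chain carbon. The neighbouring steps do not: a number 6 percentage points higher from compound 2 to compound 4 (within the scatter) for methyl in place of hydrogen on an amine nitrogen, and a number 9 percentage points higher from compound 1 to compound 4 (within the scatter) for methylamino in place of methoxy. Nothing available here accounts for the difference. The compounds shown leave open how a dimethylamino group, a longer chain ending in an amine or a carboxylic acid at this place would read in this assay.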